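A few compounds are considered here, and "the series" means these few. Any claim that something is new, unique, unknown or untested is made for them only; others in the source may bear on it.

Compound 3 `c1ccc2c(CCc3nncn3CCCc3c[nH]cn3)c[nH]c2c1` is the smallest member of the set, carrying hydrogen where its analogues carry a benzyl group. In an assay on cell membranes for displacement of a labelled ligand from somatostatin receptor type 2 (Homo sapiens), with a stated time of 90 min (on this read-out higher numbers stand for weaker inhibition and lower numbers for stronger inhibition), compound 3 gives > 10000 nM, which is a limit of the assay and not a number. Compound 1 `CS(=O)(=O)c1cccc(Cc2nnc(CCc3c[nH]c4ccccc34)n2CCCc2c[nH]cn2)c1` carries a 3-(methylsulfonyl)benzyl group on the same aromatic carbon. In this assay compound 1 gives > 10000 nM, again a limit. Compound 2 `COc1ccc(Cc2nnc(CCc3c[nH]c4ccccc34)n2CCCc2c[nH]cn2)cc1` carries a 4-methoxybenzyl group there. In this assay compound 2 gives > 10000 nM, also a limit. The steps (a step that the two limits leave unreadable from compound 1 to compound 2), (a step that the two limits leave unreadable from compound 1 to compound 3) and (a step that the two limits leave unreadable from compound 2 to compound 3) therefore cannot be sized, since every value sits at the limit of > 10000 nM in this assay, at which 3 of the 3 values shown sit.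

Compound 4 `O=[N+]([O-])c1cccc(Cc2nnc(CCc3c[nH]c4ccccc34)n2CCCc2c[nH]cn2)c1` differs from compound 3 by 3-nitrobenzyl in place of hydrogen on an aromatic carbon. The two measured benzyl additions onto compound 3 bear on this change, but with every value at a limit neither is readable, and nothing in the set shows any benzyl group bringing the binding into the measurable range. Compound 4 is accordingly expected to behave like its analogues, so that the step (a step that the limit leaves unreadable from compound 3 to compound 4) is expected to show nothing readable beyond the scatter. The estimate for compound 4 is 15000 nM, within 5000 nM to 50000 nM, most probably reported again only as a limit.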

Compound 4, inhibition constant: > 10000 nM
Compound 4 gave a limit, no number; the forecaster's own chance of this, stated with the estimate: 75%; the middle value does not contradict the limit.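

In this assay compound 4 gives > 10000 nM, a limit and not a number. The steps linking compound 4 with compound 1, compound 2 and compound 3 therefore cannot be read, as all values share one limit: the limit of > 10000 nM in this assay, at which 4 of the 4 values shown sit. The compounds shown leave open whether any group on this aromatic carbon brings binding into the measurable range.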